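The source may hold more compounds than are shown below. What is called first, only, known or untested is meant among the compounds shown, and "the series" means these compounds.

Working notes on the series. In a functional assay on DU-145 cells (Homo sapiens) for inhibition, read by trypan blue exclusion, with a stated time of 72 h (a lower number here means a stronger inhibitor, a higher number a weaker inhibitor), compound 1 `Cn1c(=O)c(S(=O)(=O)Cc2ccc(F)cc2F)cc2cnc(Nc3ccc4[nH]ccc4c3)nc21` gives 1000 nM, compound 2 `Cn1c(=O)c(S(=O)(=O)Cc2ccc(F)cc2)cc2cnc(Nc3ccc4[nH]ccc4c3)nc21` gives 30000 nM and compound 3 `Cc1ccc(S(=O)(=O)c2cc3cnc(Nc4ccc5[nH]ccc5c4)nc3n(C)c2=O)cc1` gives 750 nM. Compound 3 holds the lowest number of the three, within the scatter of compound 1 but far from compound 2: a 1.3-fold lower number from compound 1 to compound 3 (0.12 log units; within the scatter) and a 40-fold lower number from compound 2 to compound 3 (1.60 log units; beyond the scatter), while a 30-fold higher number from compound 1 to compound 2 (1.48 log units; beyond the scatter). Compound 4 `Cn1c(=O)c(S(=O)(=O)c2ccc(O)cc2)cc2cnc(Nc3ccc4[nH]ccc4c3)nc21` differs from compound 3 by hydroxy in place of methyl on an aromatic carbon. Within the data shown here, no measured step alters a substituent on a six-membered aromatic ring of carbon only attached directly to the sulfonyl sulfur, so none bears on this change directly; the one substituent step measured was large, so the number could move either way. For compound 4 the expected value is 1500 nM, with a range of 300 nM to 8000 nM. The expected step is a 2.0-fold higher number from compound 3 to compound 4 (0.30 log units; within the scatter), no firm change beyond the scatter.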

Compound 4, half-maximal inhibitory concentration: 250 nM
Estimate against measurement, compound 4: 6.0-fold (0.78 log units) above, outside the stated range (below it).
By their numbers in this assay, from the lowest: compound 4; then compounds 3 and 1 (each within the scatter of the next); then compound 2.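

The first change measured on the aromatic ring attached directly to the sulfonyl sulfur is not neutral in this assay: hydroxy in place of methyl gives a step beyond the scatter (a 3.0-fold lower number from compound 3 to compound 4 (0.48 log units; beyond the scatter)), so this position responds to its substituent. Compound 4 also separates from both benzyl sulfonyl compounds (a 4.0-fold lower number from compound 1 to compound 4 (0.60 log units; beyond the scatter); a 120-fold lower number from compound 2 to compound 4 (2.08 log units; beyond the scatter)), whereas compound 3 stayed within the scatter of compound 1.

On these data alone, whether an amine, a carboxylic acid or a methoxy group at this position would match hydroxy remains open. Nothing shown explains the step.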